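The compounds below may be only part of what the source reports. "The series", "measured", "known", "first", "only" and "open" are said of these compounds alone.

In a functional assay on A-375 cells (Homo sapiens) for antiproliferative activity (on this read-out higher numbers stand for weaker inhibition and lower numbers for stronger inhibition), compound 1 `O=C(Nc1ccc(-c2cscn2)cc1)C1CCCN(Cc2cc(F)cc(F)c2)C1` gives 1360 nM. Compound 2 `O=C(Nc1ccc(-c2cscn2)cc1)C1CCCN(Cc2cccc(C(F)(F)F)c2)C1` reads > 20000 nM, which is a limit of the assay and not a number, so it sits where no exact value is available. For the measured compounds named here, the one measured step is an at least 14-fold higher number from compound 1 to compound 2 (1.16 log units; beyond the scatter), which is large and beyond the scatter. Compound 3 `O=C(Nc1ccc(-c2cscn2)cc1)C1CCCN(Cc2ccc3cn[nH]c3c2)C1` now changes the same place again, with 1H-indazol-6-yl in place of 3-(trifluoromethyl)phenyl on a saturated chain carbon bound to an amine nitrogen in a ring. The step to compound 2, an at least 14-fold higher number from compound 1 to compound 2 (1.16 log units; beyond the scatter), bears directly on this change, since it brought in the group that now leaves and shows that the read-out can move widely with the group at this place. A single step cannot say how an indazolyl group will behave, so a return to a measurable number in this assay is expected, but not necessarily to the level of compound 1. The estimated change is an at least 5.0-fold lower number from compound 2 to compound 3 (0.69 log units; beyond the scatter), a large step towards a lower number. For compound 3 the expected value is 4000 nM, with an estimated range from 800 nM to 15000 nM.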

Compound 3, half-maximal inhibitory concentration: > 20000 nM
Compound 3: a limit, no number; the forecaster's own chance of this, stated with the estimate: 20%; at least 5.0-fold (0.69 log units) between middle value and limit.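

In this assay, the replacement of 3,5-difluorophenyl by 1H-indazol-6-yl gives an at least 14-fold higher number from compound 1 to compound 3 (1.16 log units; beyond the scatter). The loss of a measurable number at this place is therefore not confined to 3-(trifluoromethyl)phenyl: it also appears with 1H-indazol-6-yl, which brings in a hydrogen-bond donor and a hydrogen-bond acceptor that 3-(trifluoromethyl)phenyl does not have. The value of compound 3 is a limit of the assay and not a number, as is that of compound 2, so the step that joins them cannot be read and the change from 3-(trifluoromethyl)phenyl to 1H-indazol-6-yl has no measured size: the limit of > 20000 nM in this assay, at which 2 of the 3 values shown sit.

The compounds shown leave open whether the number of compound 1 depends on the fluorine atoms of 3,5-difluorophenyl or on the ring that carries them, and whether a phenyl group with a single fluorine, a methoxy group or an amine would keep a measurable number. They also leave open whether a longer chain in place of the saturated chain carbon bound to the amine nitrogen would change the read-out for any of these groups.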